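Swapping a Methylphenyl for a Thiophene on a Shared Core

The compounds below may be only part of what the source reports. "The series", "measured", "known", "first", "only" and "open" are said of these compounds alone.

For the measured compounds named here, compound 2 `Cc1cccc(Cc2nc(N)nc(N3CCN(C)CC3)n2)c1` gives the lower of the two numbers measured so far in an assay on HEK293 cells for displacement of a labelled ligand from 5-hydroxytryptamine receptor 6 (Homo sapiens) (on this read-out lower numbers stand for stronger inhibition and higher numbers for weaker inhibition), at 30 nM. Going by the values given here, its only neighbour is compound 1 `CN1CCN(c2nc(N)nc(Cc3cccc(F)c3)n2)CC1`, which in this assay gives 64 nM; the single measured step, a 2.1-fold lower number from compound 1 to compound 2 (0.33 log units; beyond the scatter), is modest but clearly beyond the scatter. Compound 3 `CN1CCN(c2nc(N)nc(Cc3cccs3)n2)CC1` differs from compound 2 by thiophen-2-yl in place of 3-methylphenyl on a saturated chain carbon bound to an aromatic carbon. Among the compounds with values here, no measured step exchanges one ring type for another; the one step on record changes only a small group on the same ring and is a weak guide here. The two measured numbers lie within a narrow band, and a ring of a different kind is expected to land near that band, most likely at a somewhat higher number. The expected step is a 2.0-fold higher number from compound 2 to compound 3 (0.30 log units; within the scatter). Compound 3 is therefore estimated at about 60 nM in this assay, with a likely range from 20 nM to 180 nM.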

Compound 3, inhibition constant: 305 nM
Beside the measured number, compound 3's estimate is 5.1-fold (0.71 log units) below it; measured number outside the range, above it.
By their numbers in this assay, from the lowest: compound 2; then compound 1; then compound 3.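

At this position, on a saturated chain carbon bound to an aromatic carbon, the type of ring matters more than the small group it carries. In this assay, thiophen-2-yl in place of 3-methylphenyl gives a 10-fold higher number from compound 2 to compound 3 (1.01 log units; beyond the scatter), and thiophen-2-yl in place of 3-fluorophenyl gives a 4.8-fold higher number from compound 1 to compound 3 (0.68 log units; beyond the scatter), both larger than the change of small group alone, a 2.1-fold lower number from compound 1 to compound 2 (0.33 log units; beyond the scatter). Nothing available explains why the ring exchange has this result.

Open, as far as these compounds go, is whether the weaker number follows from the five-membered ring, its sulfur atom, or the absence of a methyl or fluoro group on the ring. An unsubstituted phenyl, a furan-2-yl or a methyl-bearing thiophene at this place would help separate these possibilities.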